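Series notes: aminoquinoline amides, cytotoxicity on breast cancer cells

This account rests on a few compounds, and the source may have more. Where it says the series, first, only, none or still open, it means among the compounds named here.

Measured so far:
- compound 1 `C[C@@H](Nc1c(C(=O)NCc2ccc(F)cc2)nc(Br)c2cccnc12)c1ccccc1`: "not determined" (no result reported)
- compound 2 `Nc1ccc(Nc2c(C(=O)NCc3ccc(F)cc3)nc(Br)c3cccnc23)cc1`: 4000 nM
- compound 3 `C[C@H](Nc1c(C(=O)NCc2ccc(F)cc2)nc(Br)c2cccnc12)c1ccccc1`: "not determined" (no result reported)

In a functional assay on MCF7 cells (Homo sapiens) for cytotoxicity, read by MTT assay, with a stated time of 72 h (a higher number here means a weaker inhibitor, a lower number a stronger inhibitor), only compound 2 gives a number, 4000 nM. Compound 3 stands without a result in this assay, as does compound 1; the two are a pair of the same composition, since (the fact that compounds 1 and 3 differ only in the configuration as drawn). No step between measured compounds can be computed from the numbers shown, so no measured step exists for compound 3 in this assay.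

Compound 4 `COC(=O)CNc1c(C(=O)NCc2ccc(F)cc2)nc(Br)c2cccnc12` is the next entry. Relative to compound 3 the change is (methoxycarbonyl)methyl in place of 1-phenylethyl on a nitrogen on an aromatic ring. Since compound 3 carries no number, the size of the step in this assay cannot be read from a measured pair, and the expectation for compound 4 rests only on compound 2, which gives 4000 nM in this assay. Compound 4 is expected to lie in a similar or somewhat weaker range, estimated at 8000 nM, between 2000 nM and 40000 nM, with a fair chance that this assay reports only a limit.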

Compound 4, half-maximal inhibitory concentration: > 10000 nM
Compound 4: only a limit was reported (the forecaster's own chance of this, stated with the estimate: 30%); middle value at least 1.2-fold (0.09 log units) away from the limit.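

In this assay, for the compounds shown here, the first readable step at this position appears: (methoxycarbonyl)methyl in place of 4-aminophenyl on a nitrogen on an aromatic ring gives an at least 2.5-fold higher number from compound 2 to compound 4 (0.39 log units; beyond the scatter). Among the compounds with a result, only compound 2, which gives 4000 nM, keeps an aromatic ring on this nitrogen, while the group in compound 4 has no ring. The entry for compound 4 is a limit and not a number, so the full size of the step is not known: the limit of > 10000 nM in this assay, at which 1 of the 4 values shown sits.

Steps from compound 1 and compound 3 cannot be read, since neither carries a result. Also open, as far as these compounds go, is whether a carboxylic acid in place of the methyl ester, or a benzyl group or longer alkyl chain on this nitrogen, would give a number in this assay.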